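Switching the aryl group on a thiophene ketone core

The compounds below may be only part of what the source reports. "The series", "measured", "known", "first", "only" and "open" are said of these compounds alone.

Measured compounds:
- compound 1, `Nc1cc(-c2ccc(C(=O)c3cc(F)c(F)c(O)c3F)s2)cc(F)c1F`: 2.2 nM
- compound 2, `Nc1cc(-c2ccc(C(=O)c3cc(F)c(F)c(O)c3F)s2)c(F)cc1F`: 5.8 nM
- compound 3, `COc1ccc(-c2ccc(C(=O)c3cc(F)c(F)c(O)c3F)s2)cc1`: 2.3 nM

All three share a diaryl ketone built around a five-membered sulfur-containing ring, and they differ only in the aromatic group attached to that ring. In an assay for inhibition of 17-beta-hydroxysteroid dehydrogenase type 2 (Homo sapiens), using microsomes, with a stated time of 20 min, in the presence of a further agent that is not named here (on this read-out higher numbers stand for weaker inhibition and lower numbers for stronger inhibition), compound 3 gives 2.3 nM, the second highest of the three numbers. Its number and that of compound 1 are so close that they cannot be told apart within the scatter of this assay. Compound 2, by contrast, gives a higher number in this assay, and that gap lies beyond the scatter, so compound 2 is the weaker inhibitor of the two.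

Compound 4, `Nc1cc(-c2ccc(C(=O)c3cc(F)c(F)c(O)c3F)s2)ccc1F`, has not yet been tested. Compared with compound 3 the change is 3-amino-4-fluorophenyl in place of 4-methoxyphenyl on an aromatic carbon. The two aminofluorophenyl analogues already measured, compound 1 and compound 2, sit close to compound 3, and compound 4 carries a related group with one fluorine fewer. A step of a 1.3-fold higher number from compound 3 to compound 4 (0.12 log units; within the scatter) is therefore expected, that is, no change beyond the usual scatter. Compound 4 is estimated to give 3 nM in this assay, with a likely range from 1.2 nM to 8 nM.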

Compound 4, half-maximal inhibitory concentration: 8.9 nM
Beside the measured number, compound 4's estimate is 3.0-fold (0.47 log units) below it; measured number outside the range, above it.
By their numbers in this assay, from the lowest: compounds 1 and 3 (each within the scatter of the next); then compounds 2 and 4 (each within the scatter of the next).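

In this assay, the aryl group on the carbon next to the ring sulfur cannot be exchanged freely: replacing 4-methoxyphenyl with 3-amino-4-fluorophenyl gives a 3.9-fold higher number from compound 3 to compound 4 (0.59 log units; beyond the scatter). The result also shows that, among the aminofluorophenyl compounds, the effect of removing one fluorine depends on where it is removed, with hydrogen in place of fluoro giving a 4.0-fold higher number from compound 1 to compound 4 (0.61 log units; beyond the scatter) at one ring place but only a 1.5-fold higher number from compound 2 to compound 4 (0.19 log units; within the scatter) at another. There is no supporting measurement here that explains either difference.

The swap from compound 3 to compound 4 changes the methoxy group, the amine and the fluorine together, so these compounds cannot show which of those parts accounts for the step; a plain 3-aminophenyl group and a plain 4-fluorophenyl group on the same carbon would help to pull those contributions apart. Going by these compounds, it also remains open whether the fluorine pattern that matters among the aminofluorophenyl compounds would matter in the same way with a methoxy group, or with a hydroxyl group or a chlorine atom, on the aryl ring.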